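The source may report more compounds than this note shows. Statements on the series, on what has been measured and on what is new or still open speak of the compounds shown alone.

Going by the values given here, in an ADME assay on MRC5 cells (Homo sapiens) for cytotoxicity, read by fluorescence and resazurin assay, with a stated time of 3 days (a higher number here means a weaker inhibitor, a lower number a stronger inhibitor), compound 1 `Cc1cn(C2CCN(Cc3cccc(OC4CCCC4)c3)CC2)c(=O)[nH]c1=O` gives 30300 nM as the only actual number so far. Compound 2 `Cc1cn(C2CCN(Cc3cncc(Oc4cccc(Cl)c4)c3)CC2)c(=O)[nH]c1=O` reads > 64000 nM and that is a limit of the assay, not a number. Compound 3 `Cc1cn(C2CCN(Cc3cc(Oc4cccc(Cl)c4)ccn3)CC2)c(=O)[nH]c1=O` also reads > 64000 nM and that too is a limit. Among the compounds with values here, the only other mark on the scale is therefore the limit of > 64000 nM in this assay, at which 2 of the 3 values shown sit, and compound 1 is the one compound with a real reading.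

Compound 4 `Cc1cn(C2CCN(Cc3cccc(Oc4cccc(F)c4)c3)CC2)c(=O)[nH]c1=O` is still unmeasured. It has 3-fluorophenyl in place of cyclopentyl on an oxygen on an aromatic ring, a swap that counts out as 3-fluorophenyl in place of cyclopentyl on an oxygen on an aromatic ring in full.

Within the data shown here, no two measured compounds differ in just one place, so no measured step can serve as a guide. Compound 2 also carries an aromatic ring on that oxygen and reads > 64000 nM as a limit, so a small step toward weaker inhibition is expected, perhaps no larger than the usual scatter. The expected change is a 1.5-fold higher number from compound 1 to compound 4 (0.17 log units; within the scatter) as estimated here. The estimate for compound 4 is 45000 nM with an expected range of 20000 nM to 64000 nM as the likely span.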

Compound 4, half-maximal inhibitory concentration: > 64000 nM
Compound 4 ended at the assay's limit; the forecaster's own chance of this, stated with the estimate: 40%; middle value at least 1.4-fold (0.15 log units) away from the limit.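

In this assay compound 4 reads > 64000 nM, which is a limit of the assay and not a number. Compound 2 and compound 3 each differ from compound 1 in more than one place. Going by these compounds alone, compound 4 still gives the first readable comparison at this position: putting 3-fluorophenyl in place of cyclopentyl on an oxygen on an aromatic ring gives an at least 2.1-fold higher number from compound 1 to compound 4 (0.32 log units; beyond the scatter). This single change is therefore enough to take the shared core from a real reading to the end of the scale, and compound 1 remains the only compound with a number: the limit of > 64000 nM in this assay, at which 3 of the 4 values shown sit.

The limit hides how far the true reading of compound 4 lies beyond the end of the scale, so the step has a lower bound but no known size. As far as these compounds go, it also remains open whether the aromatic ring or its fluorine accounts for the step, a question that a plain phenyl on that oxygen could help to separate, while an open chain such as butyl would test whether a ring is needed there at all.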